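Pyridyl ether stilbenes: amide substituent and antiproliferative activity

The source may hold more compounds than are shown below. What is called first, only, known or untested is meant among the compounds shown, and "the series" means these compounds.

Measured compounds:
compound 1 `O=C(Nc1ccccc1)c1cc(Oc2ccc(/C=C/c3ccncc3)cc2)ccn1` — > 100000 nM
compound 2 `CC(C)NC(=O)c1cc(Oc2ccc(/C=C/c3ccncc3)cc2)ccn1` — 33700 nM

Among the compounds with values here, in a functional assay on HepG2 cells (Homo sapiens) for antiproliferative activity, read by CCK-8 assay, with a stated time of 48 h (on this read-out higher numbers stand for weaker inhibition and lower numbers for stronger inhibition), compound 2 gives 33700 nM, the only numeric value shown. For compound 1 the result is a limit, > 100000 nM, as noted in the limit of > 100000 nM in this assay, at which 1 of the 2 values shown sits. Within the data shown here, the one measured step, an at least 2.9-fold lower number from compound 1 to compound 2 (0.47 log units; beyond the scatter), replaces phenyl with isopropyl on the amide-type nitrogen and lowers the number beyond the scatter.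

Compound 3 `O=C(NC1CC1)c1cc(Oc2ccc(/C=C/c3ccncc3)cc2)ccn1` carries the change (cyclopropyl in place of isopropyl on an amide-type nitrogen), at the same amide-type nitrogen. The measured step concerns a different exchange at that position, so it bears only loosely on this one; it shows that an alkyl group there is compatible with a numeric value, but nothing about isopropyl against cyclopropyl. The step to compound 3 is therefore expected to stay within the scatter, a 1.1-fold lower number from compound 2 to compound 3 (0.05 log units; within the scatter), with no clear direction. Compound 3 is estimated at 30000 nM, between 10000 nM and 100000 nM.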

Compound 3, half-maximal inhibitory concentration: 77500 nM
Estimate against measurement, compound 3: 2.6-fold (0.41 log units) below, and the stated range covers the measured number.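

In this assay, cyclopropyl in place of isopropyl on the amide-type nitrogen gives a 2.3-fold higher number from compound 2 to compound 3 (0.36 log units; beyond the scatter), so this position separates two groups of 3 carbon heavy atoms, one with a three-membered ring and one without. Of the two compounds with numeric values, compound 2, with the open-chain isopropyl, therefore gives the lower number. Cyclopropyl in place of phenyl on the amide-type nitrogen gives an at least 1.2-fold lower number from compound 1 to compound 3 (0.11 log units; that floor lies within the scatter), and this step cannot be read further, because it starts from a limit: the limit of > 100000 nM in this assay, at which 1 of the 3 values shown sits.

The compounds shown leave open how a longer chain such as n-butyl, a larger ring such as cyclohexyl, or a chain ending in an amine would read at this nitrogen. They also leave open whether the gap between isopropyl and cyclopropyl would hold with other groups on the shared core.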